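This account rests on a few compounds, and the source may have more. Where it says the series, first, only, none or still open, it means among the compounds named here.

In a functional assay on PC-3 cells (Homo sapiens) for cytotoxicity, read by colorimetric assay and MTT assay (a lower number here means a stronger inhibitor, a higher number a weaker inhibitor), compound 1 (`CCOC(=O)Cn1c(=O)c(-c2ccc(OC)cc2)cc2c(OC)cc(OC)cc21`) gives 10000 nM and compound 2 (`COc1ccc(-c2cc3c(OC)cc(OC)cc3n(CC#N)c2=O)cc1`) gives 10000 nM, while compound 3 (`COc1ccc(-c2cc3c(OC)cc(OC)cc3n(CCCC#N)c2=O)cc1`) gives 10000 nM and so stands level with both. Within the data shown here, three measured steps bear on the next change, and all three stay within the scatter: (no change at the digits printed from compound 1 to compound 2 (within the scatter)), (no change at the digits printed from compound 1 to compound 3 (within the scatter)) and (no change at the digits printed from compound 2 to compound 3 (within the scatter)). Compound 4 (`COc1ccc(-c2cc3c(OC)cc(OC)cc3n(CC(=O)O)c2=O)cc1`) departs from compound 3 by carboxy in place of 2-cyanoethyl on a saturated chain carbon bound to an aromatic nitrogen in one change: carboxy in place of 2-cyanoethyl on a saturated chain carbon bound to an aromatic nitrogen. Among the measured compounds shown here, no measured compound carries the carboxy group, so the guidance is indirect. Given compound 3 at 10000 nM and those three steps, no step beyond the scatter is expected in this assay here. The estimated step is no change at the digits printed from compound 3 to compound 4 (within the scatter) and no direction is expected. For compound 4 the estimated value is 10000 nM with an expected range from 4000 nM to 20000 nM.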

Compound 4, half-maximal inhibitory concentration: 10000 nM
Compound 4: the middle estimate sits on the measured number at the digits printed; the range from low to high includes it.
By their numbers in this assay, from the lowest: compounds 1, 2, 3 and 4 (each within the scatter of the next).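

In this assay the carboxy group, which counts one hydrogen-bond donor where 2-cyanoethyl counts none, reads level with the earlier groups at this position, with carboxy in place of 2-cyanoethyl (no change at the digits printed from compound 3 to compound 4 (within the scatter)) and in place of cyano (no change at the digits printed from compound 2 to compound 4 (within the scatter)). Hydrogen in place of ethyl on an oxygen next to a carbonyl group likewise gives (no change at the digits printed from compound 1 to compound 4 (within the scatter)). Nothing given here accounts for this reading. Open, going by these compounds, is whether an amine or an amide on this chain would read differently, and whether changes to the shared core would move the number.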